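Changing One Group on a Weakly Active Compound

The source may report more compounds than this note shows. Statements on the series, on what has been measured and on what is new or still open speak of the compounds shown alone.

For the measured compounds named here, only two compounds have numbers so far in a functional assay on MCF7 cells (Homo sapiens) for antiproliferative activity, read by sulforhodamine B assay, with a stated time of 3 days; on this read-out higher numbers stand for weaker inhibition and lower numbers for stronger inhibition. Compound 1 `C=CCOc1ncnc2c1ncn2C1COc2ccccc2CO1` gives 5040 nM. Compound 2 `c1ccc2c(c1)COC(n1cnc3ncnc(OCC4CCCCC4)c31)CO2` gives 13400 nM, the higher of the two numbers, which makes it the weaker inhibitor of the pair, and the gap between them lies beyond the usual scatter.

The next compound to be tested is compound 3 `Clc1ccc(Sc2ncnc3ncn(C4COc5ccccc5CO4)c23)c(Cl)c1`. It has (2,4-dichlorophenyl)sulfanyl in place of cyclohexylmethoxy on an aromatic carbon, and the rest of the structure of compound 2 stays the same.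

Going by the values given here, no measured pair shows what this exchange does, so the expectation in this assay is a cautious one. Among the compounds with values here, it rests only on the narrow spread of the two known numbers, with compound 1 at 5040 nM as the lower one. The expected change is a 1.7-fold lower number from compound 2 to compound 3 (0.22 log units; within the scatter), a small move towards a lower number that stays within the usual scatter. For compound 3 the estimated value is 8000 nM, with an expected range of 2500 nM to 25000 nM.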

Compound 3, half-maximal inhibitory concentration: 8400 nM
For compound 3 the middle estimate is 1.1-fold (0.02 log units) below the measured one; the measured number falls inside the stated range.
By their numbers in this assay, from the lowest: compounds 1, 3 and 2 (each within the scatter of the next, the first and the last beyond it).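

In this assay, exchanging cyclohexylmethoxy for (2,4-dichlorophenyl)sulfanyl on this aromatic carbon gives a 1.6-fold lower number from compound 2 to compound 3 (0.20 log units; within the scatter), so the two compounds cannot be ranked against each other. This step shows that the position can carry either a non-aromatic ring of carbon or an aromatic ring bearing chlorine atoms without a change that stands clear of the scatter, even though the two groups differ in their ring, their linking atom and their substituents. Nothing measured here offers a reason why such different groups give numbers this close.

On these data alone, the exchange alters the ring and the linking atom together, so the contribution of each one stays open, and a plain phenylsulfanyl group or an anilino group, which has a nitrogen as its linking atom, at this carbon would help to separate them. As far as these compounds go, it also remains open whether any group at this position can bring the number well under that of compound 1 at 5040 nM, since all the values shown so far are those of weak inhibitors.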